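Methyl for isopropyl on the ring nitrogen in a maximal-response series

This account rests on a few compounds, and the source may have more. Where it says the series, first, only, none or still open, it means among the compounds named here.

Measured so far:
compound 1 `Cc1ccc(-c2ccccc2NCC2=NCCN2)n1C`: 0%
compound 2 `CC(C)n1nccc1-c1ccccc1NCC1=NCCN1`: 0%
compound 3 `CCCn1ncnc1-c1ccccc1NCC1=NCCN1`: 74%

In a functional assay with Alpha-1B adrenergic receptor (Homo sapiens) as the target, read by calcium flux (a lower number here means a smaller maximal response, a higher number a larger maximal response), compound 2 gives 0%, level with compound 1 within the scatter, and together these are the lowest of the three numbers; compound 3 lies far above compound 2, well beyond the scatter. Among the compounds with values here, no single-change step between measured compounds is available.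

Compound 4 `Cn1nccc1-c1ccccc1NCC1=NCCN1` has not been measured. Relative to compound 2 the change is methyl in place of isopropyl on an aromatic nitrogen. Compound 1 also carries a methyl on a ring nitrogen and gives 0%, so no change beyond the scatter is expected in this assay, with some allowance for a rise because compound 3 gives 74%.

Compound 4 is therefore estimated at 8%, within 0% to 45%. The expected step is a number 8 percentage points higher from compound 2 to compound 4 (within the scatter).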

Compound 4, largest response reached (reported as maximal response), in percent of the reference or control that the assay uses: 0%
The estimate for compound 4 lay 8 percentage points above the measured number, within the range that was stated.
By their numbers in this assay, from the lowest: compounds 1, 2 and 4 (each within the scatter of the next); then compound 3.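

For methyl in place of isopropyl on the aromatic nitrogen, this assay shows no change at the digits printed from compound 2 to compound 4 (within the scatter). Within the data shown here, this gives the first single-change reading at this position: with either group on this nitrogen of the five-membered aromatic ring, the maximal response stays the same, with compound 4 at 0% in this series.

Compound 3 differs from compound 2 in more than one place, so its higher number cannot be tied to any single change. Whether a longer chain ending in an amine, or a carboxylic acid, on this nitrogen would alter the response remains open, and nothing available explains the present result.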